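Compound 3 to compound 4: phenyl for 1H-indol-3-yl

The source may hold more compounds than are shown below. What is called first, only, known or untested is meant among the compounds shown, and "the series" means these compounds.

Measured in a functional assay on MGC-803 cells (Homo sapiens) for cytotoxicity, read by MTT assay, with a stated time of 72 h; on this read-out higher numbers stand for weaker inhibition and lower numbers for stronger inhibition:
- compound 1 `O=C1C(=Cc2ccc(O)cc2)C(=O)N(c2ccc(Cl)cc2)N1c1ccc(Cl)cc1`: 19500 nM
- compound 2 `O=C1C(=C/C=C/c2ccccc2)C(=O)N(c2ccc(Cl)cc2)N1c1ccc(Cl)cc1`: 5100 nM
- compound 3 `O=C1C(=Cc2c[nH]c3ccccc23)C(=O)N(c2ccc(Cl)cc2)N1c1ccc(Cl)cc1`: 21800 nM

Compound 3 shares the high end of the numbers: a 1.1-fold higher number from compound 1 to compound 3 (0.05 log units; within the scatter) lies within the scatter, whereas a 4.3-fold higher number from compound 2 to compound 3 (0.63 log units; beyond the scatter) lies beyond it. Next comes compound 4 `O=C1C(=Cc2ccccc2)C(=O)N(c2ccc(Cl)cc2)N1c1ccc(Cl)cc1`, with phenyl in place of 1H-indol-3-yl on a double-bonded chain carbon bound to a double-bonded ring carbon. All measured steps change this same place. Exchanging the two ring groups gave a 1.1-fold higher number from compound 1 to compound 3 (0.05 log units; within the scatter), and only 2-phenylethenyl moved the number beyond the scatter, with a 3.8-fold lower number from compound 1 to compound 2 (0.58 log units; beyond the scatter). Phenyl carries no such chain, so no step beyond the scatter is expected in this assay. The expected step is a 1.5-fold lower number from compound 3 to compound 4 (0.16 log units; within the scatter). The estimate for compound 4 is 15000 nM, with an expected range of 6000 nM to 38000 nM.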

Compound 4, half-maximal inhibitory concentration: 27200 nM
Estimate against measurement, compound 4: 1.8-fold (0.26 log units) below; low and high end bracket the measured number.
By their numbers in this assay, from the lowest: compound 2; then compounds 1, 3 and 4 (each within the scatter of the next).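

Replacing 1H-indol-3-yl, with its five-membered ring and hydrogen-bond donor, by phenyl gives a 1.2-fold higher number from compound 3 to compound 4 (0.10 log units; within the scatter) in this assay and removing hydroxy gives a 1.4-fold higher number from compound 1 to compound 4 (0.14 log units; within the scatter) so neither group separates these compounds from the plain phenyl compound. Phenyl in place of 2-phenylethenyl gives a 5.3-fold higher number from compound 2 to compound 4 (0.73 log units; beyond the scatter) and among these groups only 2-phenylethenyl stands apart. No measurement at hand explains that gap.

As far as these compounds go, whether a longer chain than 2-phenylethenyl, or an amine or carboxylic acid on the phenyl ring, would move the number remains open. Changes elsewhere on the shared core also remain open.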